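Swapping One Phenyl Group on Compound 3

This account rests on a few compounds, and the source may have more. Where it says the series, first, only, none or still open, it means among the compounds named here.

- compound 1 `C=CS(=O)(=O)N1CCN(c2ncnc3sc(-c4cn(S(=O)(=O)c5ccccc5)c5ccccc45)cc23)CC1` (40400 nM)
- compound 2 `C=CS(=O)(=O)N1CCN(c2nc(OC[C@H]3CCCN3C)nc3sc(-c4ccc(N5CCN(C)CC5)cc4)cc23)CC1` (760 nM)
- compound 3 `CN1CCN(c2ccc(-c3cc4c(N5CCN(C(=O)Nc6ccc(OC(F)(F)F)cc6)CC5)ncnc4s3)cc2)CC1` (4600 nM)

In a functional assay on MDA-MB-231 cells (Homo sapiens) for antiproliferative activity, read by MTT assay, with a stated time of 48 h (on this read-out lower numbers stand for stronger inhibition and higher numbers for weaker inhibition), compound 3 (4600 nM) stands in the middle of the three, with compound 2 (760 nM) lower and compound 1 (40400 nM) higher. Compound 4 `CN1CCN(c2ccc(-c3cc4c(N5CCN(C(=O)Nc6ccc(Cl)c(C(F)(F)F)c6)CC5)ncnc4s3)cc2)CC1` has not yet been measured. It carries 4-chloro-3-(trifluoromethyl)phenyl in place of the 4-(trifluoromethoxy)phenyl of compound 3, on an amide-type nitrogen (4-chloro-3-(trifluoromethyl)phenyl in place of 4-(trifluoromethoxy)phenyl on an amide-type nitrogen). Among the measured compounds shown here, no two measured compounds differ in just one place, so the data give no direct guide to this change. A shift beyond the scatter is therefore not expected in this assay, and no direction is favoured. The estimated step is small (a 1.2-fold lower number from compound 3 to compound 4 (0.06 log units; within the scatter)). Compound 4 is expected at 4000 nM (range 1400 nM to 11000 nM).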

Compound 4, half-maximal inhibitory concentration: 2220 nM
The estimate for compound 4 lay 1.8-fold (0.26 log units) above the measured number; measured number inside the range.
By their numbers in this assay, from the lowest: compound 2; then compound 4; then compound 3; then compound 1.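

In this assay, among the compounds shown here, this is the first comparison here that changes only one place, and it shows that the group on the amide-type nitrogen can shift the number. Placing 4-chloro-3-(trifluoromethyl)phenyl there instead of 4-(trifluoromethoxy)phenyl gives a 2.1-fold lower number from compound 3 to compound 4 (0.32 log units; beyond the scatter) and counts as a modest step. No measurement at hand explains this step.

The compounds shown do not separate the part played by the chlorine from that of the trifluoromethyl group. From the compounds shown here alone, how a pyridine or a cyclohexyl group would read at this nitrogen also remains open.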